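Methoxy added to the benzylsulfanyl group of compound 3

The source may hold more compounds than are shown below. What is called first, only, known or untested is meant among the compounds shown, and "the series" means these compounds.

In a functional assay on RAW264.7 cells (Mus musculus) for inhibition, with stated times of 2 h and 24 h (on this read-out lower numbers stand for stronger inhibition and higher numbers for weaker inhibition), compound 1 `COc1cc(OC)cc([C@@H]2C(O)c3cc(OC)cc(OC)c3[C@H]2c2ccccc2)c1` gives 3380 nM as its reading. Compound 2 `COc1ccc(CSC2c3cc(OC)cc(OC)c3[C@@H](c3ccc(OC)cc3)[C@@H]2c2cc(OC)cc(OC)c2)cc1` carries both (4-methoxybenzyl)sulfanyl and 4-methoxyphenyl and gives 12500 nM as its reading. Compound 3 `COc1cc(OC)cc([C@@H]2C(SCc3ccccc3)c3cc(OC)cc(OC)c3[C@H]2c2ccccc2)c1` gives > 200000 nM as a limit of the assay and not a number. This places compound 3 at the limit of > 200000 nM in this assay, at which 1 of the 3 values shown sits, with no exact position on the scale.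

Going by the values given here, the only measured step is an at least 59-fold higher number from compound 1 to compound 3 (1.77 log units; beyond the scatter) with benzylsulfanyl in place of hydroxy on a saturated ring carbon. That step is large but concerns a different change, so it bears on the next one only indirectly.

Compound 4 `COc1ccc(CSC2c3cc(OC)cc(OC)c3[C@@H](c3ccccc3)[C@@H]2c2cc(OC)cc(OC)c2)cc1` is still unmeasured. It departs from compound 3 by methoxy in place of hydrogen on an aromatic carbon and this reads as methoxy in place of hydrogen on an aromatic carbon, para to a large group, turning benzylsulfanyl into (4-methoxybenzyl)sulfanyl. Among the compounds with values here, no measured step covers this change directly. Because compound 2 gives 12500 nM as a true number a lower number is expected for compound 4 in this assay. Some chance remains that compound 4 again gives only a limit of the assay. The expected change is an at least 3.3-fold lower number from compound 3 to compound 4 (0.52 log units; beyond the scatter) towards stronger inhibition. For compound 4 the estimated value is 60000 nM with an expected range from 15000 nM to 200000 nM on this scale.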

Compound 4, half-maximal inhibitory concentration: > 200000 nM
Compound 4: a limit, no number; the forecaster's own chance of this, stated with the estimate: 35%; at least 3.3-fold (0.52 log units) between middle value and limit.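

Methoxy on the benzylsulfanyl group does not on its own lift compound 4 off the limit in this assay, so the step from compound 3 to compound 4 cannot be read, and both compounds stay at a limit of the assay and not at a number: the limit of > 200000 nM in this assay, at which 2 of the 4 values shown sit.

The methoxy of the 4-methoxyphenyl group carries more weight here: hydrogen in its place gives an at least 16-fold higher number from compound 2 to compound 4 (1.20 log units; beyond the scatter), and of the three sulfanyl compounds only compound 2, with methoxy on both aromatic groups, gives a true number. Against the hydroxy compound, the (4-methoxybenzyl)sulfanyl group with a plain phenyl gives an at least 59-fold higher number from compound 1 to compound 4 (1.77 log units; beyond the scatter), which leaves this replacement of hydroxy as unfavourable as the limit can show.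

From the compounds shown here alone, how far compound 3 and compound 4 actually lie from each other stays open, as does whether 4-methoxyphenyl alone would move the reading of the hydroxy compound. Also open, going by these compounds, is how an amine or a carboxylic acid in place of the methoxy on the benzyl group would read on this scale.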